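Swapping the Amide Side Chain of Compound 1

A few compounds are considered here, and "the series" means these few. Any claim that something is new, unique, unknown or untested is made for them only; others in the source may bear on it.

Among the measured compounds shown here, compound 1 `CCn1c(C(=O)NCCN(C)C)ccc1C(CC)(CC)c1ccc(OCC(O)C(C)(C)C)c(C)c1` gives 870 nM in a functional assay on HepG2 cells (Homo sapiens), read by MTT assay, with a stated time of 48 h (a lower number here means a stronger inhibitor, a higher number a weaker inhibitor), the lower of the two numbers measured so far. Compound 2 `CCn1c(C(=O)NCC(OC)OC)ccc1C(CC)(CC)c1ccc(OCC(O)C(C)(C)C)c(C)c1`, which differs from it only in the chain carried by the amide nitrogen, gives 23200 nM in this assay; that step is a 27-fold higher number from compound 1 to compound 2 (1.43 log units; beyond the scatter). Compound 3 `CCn1c(C(=O)N(C)CC(=O)O)ccc1C(CC)(CC)c1ccc(OCC(O)C(C)(C)C)c(C)c1` has not yet been measured. Against compound 1 it shows ((carboxymethyl)(methyl)amino in place of (2-(dimethylamino)ethyl)amino on a carbonyl carbon). For the measured compounds named here, the single measured step that bears on this change, from compound 1 to compound 2, also removed the (dimethylamino)methyl part of the chain on the amide nitrogen, and it raised the number by a large margin. The same kind of loss occurs here, so the step of a 17-fold higher number from compound 1 to compound 3 (1.24 log units; beyond the scatter) is expected to be large and upward. Going by the values given here, only one comparison supports this, so the uncertainty is wide. Compound 3 is estimated at 15000 nM, with a range from 3000 nM to 70000 nM.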

Compound 3, half-maximal inhibitory concentration: 17100 nM
Beside the measured number, compound 3's estimate is 1.1-fold (0.06 log units) below it, and the stated range covers the measured number.
By their numbers in this assay, from the lowest: compound 1; then compounds 3 and 2 (each within the scatter of the next).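

In this assay, putting (carboxymethyl)(methyl)amino in place of (2-(dimethylamino)ethyl)amino on the carbonyl carbon gives a 20-fold higher number from compound 1 to compound 3 (1.29 log units; beyond the scatter) and so shows that a second, quite different chain without the dimethylamino end also sits far from the lowest number. The two replacement chains cannot be told apart, with a 1.4-fold lower number from compound 2 to compound 3 (0.13 log units; within the scatter) as the step between them, so among these three compounds only the chain with the dimethylamino end stands apart. Nothing measured here explains why the number moves.

Compound 3 also carries a methyl on the amide nitrogen, so the (carboxymethyl)amino chain, which keeps the amide hydrogen, would be needed to separate the two changes. From the compounds shown here alone, whether the amine itself matters remains open, and a longer chain ending in dimethylamino or a chain ending in a primary amine would test this.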